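A few compounds are considered here, and "the series" means these few. Any claim that something is new, unique, unknown or untested is made for them only; others in the source may bear on it.

This account concerns two thiophenol-derived benzamides measured for cytotoxicity and a third, untested, analogue. In an ADME assay on CEM-SS cells (Homo sapiens) for cytotoxicity, read by XTT assay, with a stated time of 6 days (a lower number here means that less compound is tolerated, a higher number that more compound is tolerated), compound 1, `NC(=O)CCNC(=O)c1cccc(S)c1`, gives only a limit, > 100 uM. For the measured compounds named here, compound 2, `CCCC(=O)OCSc1ccccc1C(=O)NCCCCCNC(C)=O`, is the one member of the pair that returns a number: in this assay compound 2 gives 9.2 uM. Going by the values given here, compound 2 therefore holds the only measured position in the set, the other value being (the limit of > 100 uM in this assay, at which 1 of the 2 values shown sits), so no step between measured compounds is available and nothing can be said about how any change in structure has shifted tolerance so far.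

Compound 3, `C#CCNC(=O)CNC(=O)c1ccccc1SCOC(=O)CCC`, differs from compound 2 in one place: propargylcarbamoyl in place of 4-acetamidobutyl on a saturated chain carbon bound to an amide-type nitrogen. Among the compounds with values here, with no measured step to lean on, the expectation for this change rests on compound 2 alone, and the step from compound 2 to compound 3 in this assay is expected to be small, a 1.5-fold higher number from compound 2 to compound 3 (0.18 log units; within the scatter), in no clear direction beyond the usual scatter. Compound 3 is thus estimated to give 14 uM in this assay, within a range from 4 uM to 60 uM.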

Compound 3, half-maximal toxic concentration: 95.4 uM
Beside the measured number, compound 3's estimate is 6.8-fold (0.83 log units) below it; the whole stated range lies below it.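

In this assay, for the compounds shown here, the exchange of 4-acetamidobutyl for propargylcarbamoyl on a saturated chain carbon bound to an amide-type nitrogen gives a 10-fold higher number from compound 2 to compound 3 (1.02 log units; beyond the scatter), the first step between measured compounds in this set. It shows that this position is not indifferent to what it carries: with the rest of the structure shared, a change in this one place moves the number well beyond the scatter, towards more compound being tolerated, even though the two groups have the same counts of hydrogen-bond donors and acceptors and neither has a ring. Nothing in the data shown bears on why the number rises, so the step stands as an observation without a cause.

A single pair cannot separate the contributions of the triple bond, the carbamoyl unit and the smaller size of the entering group. From the compounds shown here alone, how a propylcarbamoyl group with no triple bond, a longer chain ending in the same propargyl amide, or a simple amine or carboxylic acid at this place would fare in this assay remains open.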